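A few compounds are considered here, and "the series" means these few. Any claim that something is new, unique, unknown or untested is made for them only; others in the source may bear on it.

Compound 1 `COc1ccc2nc(-c3ccc(N/C=C\C(=O)c4ccc(OC)c([N+](=O)[O-])c4)cc3)sc2c1`, in a functional assay on MDA-MB-231 cells (Homo sapiens) for antiproliferative activity, read by sulforhodamine B assay, with a stated time of 48 h (on this read-out higher numbers stand for weaker inhibition and lower numbers for stronger inhibition), gives 17600 nM.
Compound 2 `COc1cc(OC)c2sc(-c3ccc(N/C=C\C(=O)c4cc(OC)c(OC)c(OC)c4)c(C)c3)nc2c1` gives 13800 nM.
Compound 3 `COc1cc(OC)c2sc(-c3ccc(N/C=C\C(=O)c4cc(OC)c(OC)c(OC)c4)cc3)nc2c1` gives 15800 nM.

The three numbers lie within the usual scatter of one another, so none is set apart. Compound 4 `COc1ccc2nc(-c3ccc(N/C=C\C(=O)c4ccc(OC)c([N+](=O)[O-])c4)c(C)c3)sc2c1` remains to be measured in this assay. It shares its core with compound 1; how that core differs from the core of compound 3 is not broken down here. The change from compound 3 to compound 2 is methyl in place of hydrogen on an aromatic carbon, and it gave a 1.1-fold lower number from compound 3 to compound 2 (0.06 log units; within the scatter). The change from compound 1 to compound 4 is methyl in place of hydrogen on an aromatic carbon; it is the same kind of change, though here the methyl stands meta to a 6-methoxy-1,3-benzothiazol-2-yl group, whereas in compound 2 it stands meta to a large group. Because the earlier step of a 1.1-fold lower number from compound 3 to compound 2 (0.06 log units; within the scatter) stayed within the scatter, a similar outcome is expected, with a step of a 1.1-fold lower number from compound 1 to compound 4 (0.04 log units; within the scatter). Compound 4 is therefore estimated at 16000 nM, between 8000 nM and 32000 nM.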

Compound 4, half-maximal inhibitory concentration: 17600 nM
Compound 4: the middle estimate sits 1.1-fold (0.04 log units) below what was measured; the range from low to high includes it.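

In this assay, methyl in place of hydrogen on an aromatic carbon gave no change at the digits printed from compound 1 to compound 4 (within the scatter). Set beside the earlier step, the same change reads alike on the two cores: the same change on two cores in this assay, a 1.1-fold lower number (0.06 log units; within the scatter) from compound 3 to compound 2 and no change at the digits printed (within the scatter) from compound 1 to compound 4, 1.1-fold (0.06 log units) apart, within the scatter of two such steps. This shows only that a methyl ortho to a large group left the number within the scatter on each of these two cores; it does not show that the same would hold on any other core, and steps this small give no measurable effect to carry across.

The compounds shown leave open whether a different group at this place, such as an ethyl, an amine or a carboxylic acid, would move the number beyond the scatter. They also leave open what a methyl would do elsewhere on that ring.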